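Lengthening the ester chain: expectation for compound 3

This account rests on a few compounds, and the source may have more. Where it says the series, first, only, none or still open, it means among the compounds named here.

Measured compounds:
- compound 1, `CCCCCOC(=O)CCC(=O)N1CCN(CCCOc2cc3c(Nc4ccc(F)c(Cl)c4)ncnc3cc2OC)CC1`, 63.6%
- compound 2, `CCCCCCCOC(=O)CCC(=O)N1CCN(CCCOc2cc3c(Nc4ccc(F)c(Cl)c4)ncnc3cc2OC)CC1`, 59.1%

Both compounds were tested in a functional assay on A549 cells (Homo sapiens) for cytotoxicity, read by MTT assay, with a stated time of 24 h, tested at 40 uM; on this read-out higher numbers stand for a weaker effect at the one concentration tested and lower numbers for a stronger effect. Compound 2 has the lower of the two numbers; compound 1 gives 63.6%, and the step of a number 4.5 percentage points lower from compound 1 to compound 2 (within the scatter) lies within the scatter, so the two readings cannot be told apart with confidence.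

Compound 3, `CCCCCCCCCOC(=O)CCC(=O)N1CCN(CCCOc2cc3c(Nc4ccc(F)c(Cl)c4)ncnc3cc2OC)CC1`, has not yet been measured in this assay. It differs from compound 2 by the change (ethyl in place of hydrogen on a saturated chain carbon, seven bonds along the chain from an oxygen next to a carbonyl group). For the measured compounds named here, this is the same kind of change as the one from compound 1 to compound 2, only placed further along the chain.

Going by the values given here, the only step that bears on this change is a number 4.5 percentage points lower from compound 1 to compound 2 (within the scatter), which was small and within the scatter. A step of similar size is therefore expected for compound 3, with no change beyond the scatter likely, though a further small drop would follow the earlier step. The step of a number 4.1 percentage points lower from compound 2 to compound 3 (within the scatter) is the estimate for compound 3. In this assay compound 3 is expected to give 55%, within a range of 40% to 68%.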

Compound 3, a percentage reported as activity, at one concentration (the size of the read-out at that concentration, not a potency): 17.9%
Compound 3: middle estimate off by 37.1 percentage points, on the high side; the measured number lies below the stated range.
By their numbers in this assay, from the lowest: compound 3; then compounds 2 and 1 (each within the scatter of the next).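

In this assay, ethyl in place of hydrogen seven bonds along the chain from an oxygen next to a carbonyl group gives a number 41.2 percentage points lower from compound 2 to compound 3 (beyond the scatter) in one step, whereas the same kind of change five bonds along gave a number 4.5 percentage points lower from compound 1 to compound 2 (within the scatter) and could not be told from scatter. The size of this change therefore depends on where it is made along the ester chain, and across these three compounds the reading does not fall evenly as the chain grows: butyl in place of hydrogen five bonds along the chain gives a number 45.7 percentage points lower from compound 1 to compound 3 (beyond the scatter), with almost all of that difference arising at the last extension. For the compounds shown here, nothing measured so far gives a reason for this sharp drop.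

The compounds shown leave open whether a longer chain would hold the low reading, lower it further or bring it back up. They also leave open whether chain length alone matters, which a chain of similar size carrying an amine or a carboxylic acid could help to test, and how the effect would look across a range of concentrations instead of a single one.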